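Methyl in place of fluoro on the shared core

A few compounds are considered here, and "the series" means these few. Any claim that something is new, unique, unknown or untested is made for them only; others in the source may bear on it.

Compound 1 `COc1ccc(-c2[nH]c3cc(F)ccc3c2C=O)cc1` at 59 nM as measured
Compound 2 `COc1ccc(-c2[nH]c3ccc(F)cc3c2C=O)cc1` at 540 nM as measured

In a functional assay on MDA-MB-231 cells (Homo sapiens) for antiproliferative activity, with a stated time of 4 days (on this read-out lower numbers stand for stronger inhibition and higher numbers for weaker inhibition), compound 2 stands at 540 nM as the higher of the two numbers, beyond the scatter from compound 1. Compound 3 `COc1ccc(-c2[nH]c3ccc(C)cc3c2C=O)cc1` carries methyl in place of fluoro on an aromatic carbon relative to compound 2. Among the compounds with values here, no measured step covers this change, so no shift beyond the scatter is expected in this assay for it. The estimated 1.4-fold lower number from compound 2 to compound 3 (0.13 log units; within the scatter) stays small. Compound 3 is estimated at 400 nM with an expected range from 120 nM to 1300 nM in this read-out.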

Compound 3, half-maximal inhibitory concentration: 86 nM
The estimate for compound 3 lay 4.7-fold (0.67 log units) above the measured number; measured number below the stated range.
By their numbers in this assay, from the lowest: compounds 1 and 3 (each within the scatter of the next); then compound 2.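

In this assay this position on the shared core proves sensitive to a single-atom swap: methyl in place of fluoro gives a 6.3-fold lower number from compound 2 to compound 3 (0.80 log units; beyond the scatter) on an aromatic carbon. The two groups match in heavy-atom count, with no ring, hydrogen-bond donor, hydrogen-bond acceptor or net charge on either side, so those counts do not separate them. Nothing available accounts for the shift. As far as these compounds go, whether an ethyl group, a longer chain or an amine at this place would hold or change the number stays open. Also open, from the compounds shown here alone, is whether methyl in place of fluoro behaves the same way on compound 1.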